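From Piperazine Amide to Methyl Ester on a Shared Core

The source may hold more compounds than are shown below. What is called first, only, known or untested is meant among the compounds shown, and "the series" means these compounds.

Of the compounds shown here, three on one core have been tested in a functional assay on A549 cells (Homo sapiens) for inhibition, read by sulforhodamine B assay, with a stated time of 72 h; a higher number here means a weaker inhibitor, a lower number a stronger inhibitor. Compound 1 `CC(C)(C)NC(=O)c1c(N)sc(-c2ccc(Cl)cc2)c1-c1ccc(Cl)cc1` gives 8850 nM. Compound 2 `Nc1sc(-c2ccc(Cl)cc2)c(-c2ccc(Cl)cc2)c1C(=O)NC1CCCCC1` gives 2410 nM, and compound 3 `Nc1sc(-c2ccc(Cl)cc2)c(-c2ccc(Cl)cc2)c1C(=O)N1CCNCC1` gives 1020 nM, the lowest of the three numbers. The steps run in one direction: a 3.7-fold lower number from compound 1 to compound 2 (0.56 log units; beyond the scatter), an 8.7-fold lower number from compound 1 to compound 3 (0.94 log units; beyond the scatter), and a 2.4-fold lower number from compound 2 to compound 3 (0.37 log units; beyond the scatter), each beyond the scatter but modest in size.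

Compound 4 `COC(=O)c1c(N)sc(-c2ccc(Cl)cc2)c1-c1ccc(Cl)cc1` is the next question. The change is methoxy in place of piperazin-1-yl on a carbonyl carbon, so the group on the carbonyl carbon becomes the smallest one in the set and loses its ring and its hydrogen-bond donor. Among the compounds with values here, none of the measured steps swaps a group of this kind, and the three steps differ only in what sits on the amide-type nitrogen, so they bear on this change only loosely: they show that the number moves, modestly, when that group is altered, in either direction. A move back toward the weaker end of the set is therefore expected, and the number for compound 4 is estimated at 4000 nM, within a range of 1000 nM to 16000 nM, which means an expected step of a 3.9-fold higher number from compound 3 to compound 4 (0.59 log units; beyond the scatter).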

Compound 4, half-maximal inhibitory concentration: 5040 nM
Compound 4: the middle estimate sits 1.3-fold (0.10 log units) below what was measured, within the range that was stated.
By their numbers in this assay, from the lowest: compound 3; then compound 2; then compounds 4 and 1 (each within the scatter of the next).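

Putting methoxy on the carbonyl carbon gives up ground against two of the amides, with a 4.9-fold higher number from compound 3 to compound 4 (0.69 log units; beyond the scatter) and a 2.1-fold higher number from compound 2 to compound 4 (0.32 log units; beyond the scatter). Having an amide there is not enough on its own, however: compound 1 goes against that pattern, with a 1.8-fold lower number from compound 1 to compound 4 (0.24 log units; within the scatter), so its tert-butyl amide and the methyl ester of compound 4 cannot be told apart. No measurement available here explains these differences.

The compounds shown leave open whether the lower number of compound 3 depends on the ring nitrogens of piperazine, a question that a morpholine amide on the same core could address. They also leave open where a carboxylic acid or a longer ester, such as the ethyl ester, would fall.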